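Amide tail variation on a piperazine bis-urea series

A few compounds are considered here, and "the series" means these few. Any claim that something is new, unique, unknown or untested is made for them only; others in the source may bear on it.

In an assay on CHO cells for binding affinity to Substance-P receptor (Homo sapiens) (a higher number here means a weaker inhibitor, a lower number a stronger inhibitor), compound 1 `CCCCCN(CCCCC)C(=O)N1CCN(C(=O)N(c2ccccc2)c2ccccc2)[C@H](CO)C1` gives 280 nM and compound 2 `CCCCCN(CCCCC)C(=O)N1CCN(C(=O)N(c2ccccc2)c2ccccc2)[C@H](C(=O)NCCN(C(C)C)C(C)C)C1` gives 217 nM. Within the data shown here, the one measured step, a 1.3-fold lower number from compound 1 to compound 2 (0.11 log units; within the scatter), already shows that this position accepts a substituent change without a shift beyond the scatter. Compound 2 stands at the lower of the two numbers, but only within the scatter of compound 1. Compound 3 `CCCCCN(CCCCC)C(=O)N1CCN(C(=O)N(c2ccccc2)c2ccccc2)[C@H](C(=O)NCCN(C)C)C1` carries dimethylamino in place of diisopropylamino on a saturated chain carbon, two bonds along the chain from an amide-type nitrogen. Among the measured compounds shown here, only that one step bears on the change, and it was within the scatter, so for compound 3 no shift in this assay beyond the scatter is expected. Compound 3 is estimated at 250 nM, range 100 nM to 650 nM, which is expected to mean a 1.2-fold higher number from compound 2 to compound 3 (0.06 log units; within the scatter).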

Compound 3, half-maximal inhibitory concentration: 55 nM
Estimate against measurement, compound 3: 4.5-fold (0.66 log units) above; the whole stated range lies above it.
By their numbers in this assay, from the lowest: compound 3; then compounds 2 and 1 (each within the scatter of the next).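

The amine end of the amide tail matters in this assay: dimethylamino in place of diisopropylamino gives a 3.9-fold lower number from compound 2 to compound 3 (0.60 log units; beyond the scatter) and so moves the number beyond the scatter, which the diisopropylamino tail did not do against hydroxymethyl. The dimethylamino tail does separate from hydroxymethyl, with a 5.1-fold lower number from compound 1 to compound 3 (0.71 log units; beyond the scatter) as the step between them. Nothing available explains this difference.

Still open, going by these compounds, is whether a primary amine or a pyrrolidine at the chain end keeps the lower number. On these data alone, a longer chain between the amide nitrogen and the amine also remains untested in these compounds.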